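The compounds below may be only part of what the source reports. "The series", "measured", "known", "first", "only" and "open" are said of these compounds alone.

Measured compounds in a functional assay on L1210 cells (Mus musculus) for antiproliferative activity, with a stated time of 48 h; a higher number here means a weaker inhibitor, a lower number a stronger inhibitor:
- compound 1, `C=C(Br)C(=O)Nc1ccc(C(=O)/C=C/c2ccc(OC)cc2)cc1`: 900 nM
- compound 2, `C=C(Br)C(=O)Nc1ccc(C(=O)/C=C/c2ccc(OC)cc2OC)cc1`: 520 nM
- compound 3, `C=C(Br)C(=O)Nc1ccc(C(=O)/C=C/c2cc(OC)cc(OC)c2)cc1`: 2700 nM

For the measured compounds named here, the one measured step is a 1.7-fold lower number from compound 1 to compound 2 (0.24 log units; within the scatter), the change being (methoxy in place of hydrogen on an aromatic carbon). Compound 3 stands highest of the three; the difference between its core and that of compound 1 is not broken down here.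

Compound 4, `C=C(Br)C(=O)Nc1ccc(C(=O)/C=C/c2cc(OC)c(OC)c(OC)c2)cc1`, is not yet measured in this assay. It differs from compound 3 by methoxy in place of hydrogen on an aromatic carbon. This is the same kind of change as that from compound 1 to compound 2, not the same: there the entering methoxy sat ortho to a large group and meta to a methoxy group, here it sits ortho to two methoxy groups and para to a large group.

The expected step from compound 3 to compound 4 is a 1.5-fold lower number from compound 3 to compound 4 (0.18 log units; within the scatter), resting on the earlier step of a 1.7-fold lower number from compound 1 to compound 2 (0.24 log units; within the scatter), which stayed within the scatter. For compound 4 the estimate is 1800 nM, between 700 nM and 4500 nM.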

Compound 4, half-maximal inhibitory concentration: 1500 nM
Compound 4: middle estimate off by 1.2-fold (0.08 log units), on the high side; low and high end bracket the measured number.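

In this assay the new step is a 1.8-fold lower number from compound 3 to compound 4 (0.26 log units; within the scatter) for methoxy in place of hydrogen on an aromatic carbon, and it agrees with the earlier step on the other core: the same change on two cores in this assay, a 1.7-fold lower number (0.24 log units; within the scatter) from compound 1 to compound 2 and a 1.8-fold lower number (0.26 log units; within the scatter) from compound 3 to compound 4, 1.0-fold (0.02 log units) apart, within the scatter of two such steps. The change therefore carries between these two cores with no detectable difference in size, even though the methoxy enters a different place on the ring in each. Both steps lie within the scatter, so neither shows on its own that the methoxy moves the read-out, and two cores cannot establish that the change transfers across the wider series.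

Still open, going by these compounds, is whether another group on the same aromatic carbon, such as a hydroxyl, an amine or an ethoxy chain, would give a step beyond the scatter. Also open, on these data alone, is whether the same agreement would hold on a third core.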